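Trimethoxybenzoyl pyrroles: halogenated phenyl on the ring carbon

This account rests on a few compounds, and the source may have more. Where it says the series, first, only, none or still open, it means among the compounds named here.

Measured so far in a functional assay on MCF7 cells (Homo sapiens) for cytotoxicity, read by MTT assay, with a stated time of 96 h; a higher number here means a weaker inhibitor, a lower number a stronger inhibitor:
compound 1 `COc1cc(C(=O)c2cn(-c3ccccc3C)cc2-c2ccccc2)cc(OC)c1OC` gives 2200 nM
compound 2 `COc1cc(C(=O)c2cn(-c3ccc(N)cc3)cc2-c2ccccc2)cc(OC)c1OC` gives 35 nM
compound 3 `COc1cc(C(=O)c2cn(-c3ccccc3)cc2-c2ccccc2Cl)cc(OC)c1OC` gives 76 nM

Compound 3 stands second highest of the three numbers. Its nearest neighbour is compound 2, whose value lies lower and beyond the scatter; the furthest is compound 1, whose value lies higher and beyond the scatter. Among the compounds with values here, no computed step links compound 3 with either of them, so only the bare values can be compared.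

Within the data shown here, the one measured step, a 63-fold lower number from compound 1 to compound 2 (1.80 log units; beyond the scatter), concerns the group on the aromatic nitrogen and is large.

Compound 4 `COc1cc(C(=O)c2cn(-c3ccccc3)cc2-c2cc(F)ccc2F)cc(OC)c1OC` differs from compound 3 elsewhere: 2,5-difluorophenyl in place of 2-chlorophenyl on an aromatic carbon. Nothing measured here touches the group on this aromatic carbon, so the step from compound 1 to compound 2 does not bear directly on it, and no direction can be argued from data. The halogenated phenyl of compound 3 is kept in kind, with two fluorines in place of one chlorine.

Compound 4 is therefore expected to land near compound 3, the expected step being a 1.3-fold higher number from compound 3 to compound 4 (0.12 log units; within the scatter), within or only slightly beyond the scatter. Compound 4 is estimated at 100 nM, with a range from 30 nM to 400 nM.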

Compound 4, half-maximal inhibitory concentration: 230 nM
Compound 4: the middle estimate sits 2.3-fold (0.36 log units) below what was measured; the range from low to high includes it.
By their numbers in this assay, from the lowest: compound 2; then compound 3; then compound 4; then compound 1.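

In this assay, the group on this aromatic carbon, two ring bonds from the ring nitrogen, turns out not to be interchangeable among halogenated phenyls: 2,5-difluorophenyl in place of 2-chlorophenyl gives a 3.0-fold higher number from compound 3 to compound 4 (0.48 log units; beyond the scatter). Within the data shown here, until now the only measured step concerned the group on the aromatic nitrogen, so this is the first measured sign that the number also responds to the halogens on the phenyl at this carbon, although the change is modest beside a 63-fold lower number from compound 1 to compound 2 (1.80 log units; beyond the scatter). Nothing at hand explains the direction or the size of this step.

The single step swaps 2-chlorophenyl for 2,5-difluorophenyl in one move, so the compounds shown cannot separate the loss of the chlorine from the entry of either fluorine, and they give no reference with a plain phenyl on this carbon alongside the plain phenyl on the ring nitrogen. Also open, on these data alone, are non-halogen groups on this phenyl, such as a methoxy or a hydroxyl, and whether the 4-aminophenyl of compound 2 on the ring nitrogen would combine with either halogenated phenyl.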